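Moving the amine on a cyanophenyl series

The compounds below may be only part of what the source reports. "The series", "measured", "known", "first", "only" and "open" are said of these compounds alone.

Compound 1 `COc1cc2c(Nc3ccc(C#N)cc3)ncnc2cc1OCCCN1CCCC1`: 16200 nM
Compound 2 `CCOC(=O)C1CCN(CCCOc2cc3ncnc(Nc4ccc(C#N)cc4)c3cc2OC)CC1`: 34900 nM
Compound 3 `COc1cc2c(Nc3cccc(C#N)c3)ncnc2cc1OCCCN1CCCC1`: 33900 nM
Compound 4 `CCN1CCN(CCCOc2cc3ncnc(Nc4cccc(C#N)c4)c3cc2OC)CC1`: not yet measured

In a functional assay on MCF7 cells (Homo sapiens) for antiproliferative activity, read by MTT assay, with a stated time of 72 h (a higher number here means a weaker inhibitor, a lower number a stronger inhibitor), compound 3 sits within the usual scatter of compound 2, and its number stands clearly above that of compound 1: a 2.1-fold higher number from compound 1 to compound 3 (0.32 log units; beyond the scatter). That step alters a different group, so it says little here. Compound 4 differs from compound 3 in one group: 4-ethylpiperazin-1-yl in place of pyrrolidin-1-yl on a saturated chain carbon, three bonds along the chain from an oxygen on an aromatic ring. The nearest guide is another replacement of pyrrolidin-1-yl, which gave a 2.2-fold higher number from compound 1 to compound 2 (0.33 log units; beyond the scatter). The entering group there is not the same, so a small upward step in this assay is expected, and the estimate is a 1.5-fold higher number from compound 3 to compound 4 (0.17 log units; within the scatter). For compound 4 the expected value is 50000 nM, with an estimated range of 20000 nM to 110000 nM.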

Compound 4, half-maximal inhibitory concentration: 20000 nM
The estimate for compound 4 lay 2.5-fold (0.40 log units) above the measured number, within the range that was stated.
By their numbers in this assay, from the lowest: compounds 1, 4, 3 and 2 (each within the scatter of the next, the first and the last beyond it).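

In this assay the change from 3-(pyrrolidin-1-yl)propyl to 3-(4-ethylpiperazin-1-yl)propyl, which brings in a six-membered ring with 2 hetero atoms, stays within the scatter (a 1.7-fold lower number from compound 3 to compound 4 (0.23 log units; within the scatter)). A replacement of pyrrolidin-1-yl at this place therefore need not move the number beyond the scatter, as the earlier replacement did (a 2.2-fold higher number from compound 1 to compound 2 (0.33 log units; beyond the scatter)). Nothing on hand explains this result.

The compounds shown leave open whether 4-ethylpiperazin-1-yl would behave the same way alongside 4-cyanophenyl. They also leave open what a morpholine ring or an open-chain diethylamino group would do at this place.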